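Benzyl for Methyl on the Thioether of Compound 3

The source may report more compounds than this note shows. Statements on the series, on what has been measured and on what is new or still open speak of the compounds shown alone.

Among the compounds with values here, compound 3 `CSc1nc(=O)ccn1[C@@H]1O[C@H](COP(=O)(O)O)[C@@H](O)[C@H]1O` is the only member of this small set to give a number in an in vitro functional assay on 1321-N1 cells for agonist activity at P2Y purinoceptor 2 (Homo sapiens), read by scintillation proximity assay and inositol phosphate accumulation (a lower number here means that less compound is needed, a higher number that more compound is needed for the effect), where compound 3 gives 2900 nM. Compound 1 `CNc1nc(=O)ccn1[C@@H]1O[C@H](COP(=O)(O)O)[C@@H](O)[C@H]1O` reaches only a limit of the assay, compound 1 giving > 100000 nM in this assay. Compound 2 `Nc1nc(=O)ccn1[C@@H]1O[C@H](COP(=O)(O)O)[C@@H](O)[C@H]1O` likewise reaches only a limit, compound 2 giving > 100000 nM in this assay. The step that the two limits leave unreadable from compound 1 to compound 2 is therefore unreadable, whereas an at least 34-fold lower number from compound 1 to compound 3 (1.53 log units; beyond the scatter) and an at least 34-fold lower number from compound 2 to compound 3 (1.53 log units; beyond the scatter) show that the methylsulfanyl group matters greatly. Compound 4 `O=c1ccn([C@@H]2O[C@H](COP(=O)(O)O)[C@@H](O)[C@H]2O)c(SCc2ccccc2)n1` keeps that sulfur and differs from compound 3 by phenyl in place of hydrogen on a saturated chain carbon bound to a sulfur. Within the data shown here, none of the measured steps touches the carbon beyond the sulfur, so the three measured compounds offer no direct guide; the expectation rests on compound 3 alone, with 2900 nM as the anchor. Compound 4 is estimated to lie near compound 3, with a step of a 1.4-fold higher number from compound 3 to compound 4 (0.14 log units; within the scatter) expected in this assay. Compound 4 is thus expected at about 4000 nM, within a range from 800 nM to 30000 nM.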

Compound 4, half-maximal effective concentration: >= 100000 nM
Compound 4 was reported as a limit; the forecaster's own chance of this, stated with the estimate: 15%; middle value at least 25-fold (1.39 log units) away from the limit.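

Phenyl in place of hydrogen on a saturated chain carbon bound to a sulfur gives an at least 34-fold higher number from compound 3 to compound 4 (1.53 log units; beyond the scatter) in this assay, so keeping the sulfur does not by itself keep the number seen for compound 3. Compound 1, compound 2 and compound 3 differ only in the group on the aromatic carbon, whereas this step shows that the group beyond the sulfur matters as well. Compound 4 stands at a limit and not at a number: the limit of >= 100000 nM in this assay, at which 1 of the 4 values shown sits.

The steps from compound 1 and from compound 2 to compound 4 cannot be read, and the compounds shown do not tell how far the number for compound 4 lies beyond its limit. They also leave open whether ethyl or a longer chain on the sulfur, or a benzyl carrying a carboxylic acid, would give a number in this assay.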